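Replacing Oxan-4-yl with Isopropyl on Compound 2

The source may hold more compounds than are shown below. What is called first, only, known or untested is meant among the compounds shown, and "the series" means these compounds.

- compound 1 `Cc1cc(Nc2nc(NCc3ccc(Br)cc3)nc3[nH]ncc23)n[nH]1`: 5340 nM
- compound 2 `Cc1cc(Nc2nc(NCc3ccc(Cl)cc3)nc3c2cnn3C2CCOCC2)n[nH]1`: 1550 nM

In a functional assay on MCF7 cells (Homo sapiens) for inhibition, read by MTT assay, with a stated time of 5 days (a higher number here means a weaker inhibitor, a lower number a stronger inhibitor), compound 2 gives 1550 nM, and compound 1 gives 5340 nM. Compound 2 has the lower of the two numbers, and the gap between them lies beyond the scatter. These two compounds differ in more than one place, so they do not isolate any single change. Compound 3 `Cc1cc(Nc2nc(NCc3ccc(Cl)cc3)nc3c2cnn3C(C)C)n[nH]1` differs from compound 2 by isopropyl in place of oxan-4-yl on an aromatic nitrogen. For the measured compounds named here, no measured pair shows this change. The expected result, a 1.1-fold lower number from compound 2 to compound 3 (0.04 log units; within the scatter), is a small step within the scatter, with no firm direction. For compound 3 the estimate is 1400 nM, within a range of 500 nM to 4000 nM.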

Compound 3, half-maximal inhibitory concentration: 2040 nM
Compound 3: the middle estimate sits 1.5-fold (0.16 log units) below what was measured; measured number inside the range.
By their numbers in this assay, from the lowest: compounds 2 and 3 (each within the scatter of the next); then compound 1.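

In this assay isopropyl in place of oxan-4-yl on an aromatic nitrogen gives a 1.3-fold higher number from compound 2 to compound 3 (0.12 log units; within the scatter) and so makes no clear difference. At this position, then, a group with no ring and no hydrogen-bond acceptor serves about as well as the six-membered ring with its oxygen. No measurement here explains this result.

Compound 1 differs from compound 2 and compound 3 in more than one place, so the effect of having no group on this nitrogen stays unsettled. From the compounds shown here alone, whether an amine or a longer chain here would move the number beyond the scatter also remains open.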